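The source may hold more compounds than are shown below. What is called first, only, known or untested is meant among the compounds shown, and "the series" means these compounds.

Measured compounds:
compound 1 `CCOC(=O)C1=Cc2ccccc2OC1(OCc1cn(CC(=O)Nc2ccccc2F)nn1)C(F)(F)F` — 49900 nM
compound 2 `CCOC(=O)C1=Cc2ccccc2OC1(OCc1cc(-c2ccc(Br)cc2)no1)C(F)(F)F` — 52300 nM
compound 3 `CCOC(=O)C1=Cc2ccccc2OC1(OCc1cc(-c2cccc(C(F)(F)F)c2)no1)C(F)(F)F` — 21400 nM

All three were read in a functional assay on HeLa cells (Homo sapiens) for inhibition, read by MTT assay, with a stated time of 24 h; on this read-out higher numbers stand for weaker inhibition and lower numbers for stronger inhibition. Compound 1 stands second highest of the three numbers; its nearest neighbour is compound 2, whose number lies within the scatter of that of compound 1, and its furthest is compound 3, which gives a number beyond the scatter and lower. Going by the values given here, the only step between compounds that differ in one place is a 2.4-fold lower number from compound 2 to compound 3 (0.39 log units; beyond the scatter), a change on an aromatic carbon of a different part of the shared core.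

Compound 4 `CCOC(=O)C1=Cc2ccccc2OC1(OCc1cn(CC(=O)NC2CCCCC2)nn1)C(F)(F)F` has not yet been measured. It differs from compound 1 by cyclohexyl in place of 2-fluorophenyl on an amide-type nitrogen. Among the compounds with values here, no measured step touches the amide-type nitrogen, so nothing among the measured compounds speaks for a step in this assay beyond the scatter in either direction. The estimate for compound 4 therefore means a step of a 1.0-fold higher number from compound 1 to compound 4 (0.00 log units; within the scatter), which is expected to stay within the scatter. Compound 4 is thus estimated at 50000 nM, with a range from 20000 nM to 125000 nM.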

Compound 4, half-maximal inhibitory concentration: 11400 nM
For compound 4 the middle estimate is 4.4-fold (0.64 log units) above the measured one; the whole stated range lies above it.
By their numbers in this assay, from the lowest: compounds 4 and 3 (each within the scatter of the next); then compounds 1 and 2 (each within the scatter of the next).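

In this assay, going by these compounds alone, the group on the amide-type nitrogen turns out to matter: cyclohexyl in place of 2-fluorophenyl gives a 4.4-fold lower number from compound 1 to compound 4 (0.64 log units; beyond the scatter) and is the first step read at this position. Within the data shown here, the earlier compounds offered only one group here, so they could not show that this nitrogen responds to a change or that a non-aromatic ring of six carbons is accepted there. Nothing measured on these compounds accounts for the step, and its cause stays unexplained.

Since the ring loses its aromatic character and its fluorine together in this single pair, the compounds shown leave open which of the two differences carries the step. They also leave open how an unsubstituted phenyl, a cyclopentyl ring or a longer alkyl chain on this nitrogen would read.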